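The source may hold more compounds than are shown below. What is called first, only, known or untested is meant among the compounds shown, and "the series" means these compounds.

Three compounds share one core and differ only in the ring attached to an amine nitrogen. Compound 1 `O=C1C(Nc2ccccc2)=CC(=O)c2c1nc1n2[C@H]2OC[C@@H](O)[C@H]2OC1` carries a plain phenyl there, compound 2 `Cc1ccc(NC2=CC(=O)c3c(nc4n3[C@H]3OC[C@@H](O)[C@H]3OC4)C2=O)cc1C` a 3,4-dimethylphenyl and compound 3 `O=C1C=C(Nc2cccc(F)c2)C(=O)c2c1nc1n2[C@H]2OC[C@@H](O)[C@H]2OC1` a 3-fluorophenyl. In a functional assay on ECa-109 cells for inhibition, with ECa-109 cell line (Homo sapiens) as the target, read by sulforhodamine B assay (a lower number here means a stronger inhibitor, a higher number a weaker inhibitor), compound 1 gives 3560 nM, compound 2 gives 4090 nM and compound 3 gives 7030 nM. Going by the values given here, the only single-point step among them, a 1.1-fold higher number from compound 1 to compound 2 (0.06 log units; within the scatter), shows that adding two methyl groups to the phenyl leaves the number essentially unchanged. Compound 3 has the highest number of the three, but its gaps to compound 2 and to compound 1 both fall within the scatter, so no real ordering can be drawn from these values.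

Compound 4 `O=C1C=C(Nc2ccc(I)cc2)C(=O)c2c1nc1n2[C@H]2OC[C@@H](O)[C@H]2OC1` is not yet measured. Its difference from compound 3 is 4-iodophenyl in place of 3-fluorophenyl on an amine nitrogen. Among the compounds with values here, the one measured step, a 1.1-fold higher number from compound 1 to compound 2 (0.06 log units; within the scatter), bears on it only loosely, since it also exchanges one ring on that nitrogen for another and produced no change beyond the scatter. Nothing measured here speaks for a halogen swap on this ring, so the step of a 1.4-fold lower number from compound 3 to compound 4 (0.15 log units; within the scatter) is expected to stay within the scatter. Compound 4 is therefore estimated at 5000 nM, with a range from 2000 nM to 12000 nM.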

Compound 4, half-maximal inhibitory concentration: 2300 nM
The estimate for compound 4 lay 2.2-fold (0.34 log units) above the measured number; measured number inside the range.
By their numbers in this assay, from the lowest: compounds 4, 1, 2 and 3 (each within the scatter of the next, the first and the last beyond it).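

The step of a 3.1-fold lower number from compound 3 to compound 4 (0.49 log units; beyond the scatter) in this assay is the first change on this amine nitrogen shown to go beyond the scatter, although its size is modest. The earlier step, a 1.1-fold higher number from compound 1 to compound 2 (0.06 log units; within the scatter), left the number essentially unchanged, whereas this one shows that the ring on this nitrogen can affect the read-out, so the position is not indifferent to every exchange. Two things change together here, the halogen and the place given in the ring's name, and nothing shown gives a reason for the step or says which of the two matters.

A 4-fluorophenyl and a 3-iodophenyl on the same nitrogen would pull those two changes apart, and a 4-chlorophenyl or 4-bromophenyl would show whether the number follows the identity of the halogen in a steady way. Going by these compounds, it also remains open how this position would respond to a ring carrying something other than a halogen or methyl group, such as a methoxy group, an amine or a carboxylic acid.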